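The compounds below may be only part of what the source reports. "The series", "measured", "known", "first", "only" and "open" are said of these compounds alone.

Measured in a functional assay on MCF7 cells (Homo sapiens) for inhibition, read by MTT assay, with a stated time of 48 h; on this read-out lower numbers stand for stronger inhibition and higher numbers for weaker inhibition:
Compound 1 `COc1ccc(/C=C/c2cc(OC)cc(OC)c2/C=C/C(=O)N2CCCCC2C)cc1`: 4350 nM
Compound 2 `C#CCNC(=O)/C=C/c1c(/C=C/c2ccc(OC)cc2)cc(OC)cc1OC`: 4560 nM
Compound 3 `COc1ccc(/C=C/c2cc(OC)cc(OC)c2/C=C/C(=O)Nc2cc(OC)c(OC)c(OC)c2)cc1`: 7010 nM

The three numbers lie close together, and compound 2, at 4560 nM, cannot be told apart from the other two. Compound 4 `COc1ccc(/C=C/c2cc(OC)cc(OC)c2/C=C/C(=O)N2CCCC2)cc1` keeps the core of compound 2 but carries pyrrolidin-1-yl in place of propargylamino on a carbonyl carbon. Two measured steps changed the group at this same amide. Replacing 2-methylpiperidin-1-yl with propargylamino gave a 1.0-fold higher number from compound 1 to compound 2 (0.02 log units; within the scatter), and the 3,4,5-trimethoxyphenyl change gave a 1.5-fold higher number from compound 2 to compound 3 (0.19 log units; within the scatter). Both lie within the scatter, so neither points to a real shift. In this assay, the step of a 1.0-fold lower number from compound 2 to compound 4 (0.01 log units; within the scatter) is therefore expected to stay within the scatter, with no direction favoured. The estimated value for compound 4 is 4500 nM, with an expected range of 1900 nM to 10500 nM.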

Compound 4, half-maximal inhibitory concentration: 4200 nM
Beside the measured number, compound 4's estimate is 1.1-fold (0.03 log units) above it, and the stated range covers the measured number.
By their numbers in this assay, from the lowest: compounds 4, 1, 2 and 3 (each within the scatter of the next).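

In this assay, pyrrolidin-1-yl, which has no hydrogen-bond donor, replaces propargylamino and its amide hydrogen, and a 1.1-fold lower number from compound 2 to compound 4 (0.04 log units; within the scatter) stays within the scatter. A five-membered non-aromatic ring on the carbonyl carbon also reads the same as 2-methylpiperidin-1-yl, with a 1.0-fold lower number from compound 1 to compound 4 (0.02 log units; within the scatter). The amide hydrogen therefore shows no measurable effect on the number in this comparison. As far as these compounds go, whether a longer chain ending in an amine, or a carboxylic acid, at this carbonyl carbon would move the number beyond the scatter stays open. No available evidence explains why these groups give such close numbers.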